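Swapping the chlorophenyl end for a phenylethenyl chain

The source may hold more compounds than are shown below. What is called first, only, known or untested is meant among the compounds shown, and "the series" means these compounds.

Among the compounds with values here, in an assay on isolated protein for inhibition of sphingomyelin phosphodiesterase (Homo sapiens), read by fluorescence, with a stated time of 30 min (a lower number here means a stronger inhibitor, a higher number a weaker inhibitor), compound 1 `O=C(NO)c1cccc(OCc2ccc(-c3ccc(Cl)cc3)cc2)c1` gives 8960 nM, the higher of the two numbers measured so far; compound 2 `COc1ccc(C(=O)NO)cc1OCc1ccc(-c2ccc(Cl)cc2)cc1` gives 340 nM. Within the data shown here, the one measured step, a 26-fold lower number from compound 1 to compound 2 (1.42 log units; beyond the scatter), concerns a different part of the shared core. Compound 3 `O=C(NO)c1cccc(OCc2ccc(/C=C/c3ccccc3)cc2)c1` differs from compound 1 by 2-phenylethenyl in place of 4-chlorophenyl on an aromatic carbon. Among the measured compounds shown here, no measured step bears on this change, so nothing points to a shift beyond the scatter in this assay. Compound 3 is therefore expected to give about 7000 nM, within 2500 nM to 25000 nM. That estimate means an expected step of a 1.3-fold lower number from compound 1 to compound 3 (0.11 log units; within the scatter).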

Compound 3, half-maximal inhibitory concentration: > 100000 nM
Compound 3 ended at the assay's limit; the forecaster's own chance of this, stated with the estimate: 10%; at least 14-fold (1.15 log units) between middle value and limit.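

In this assay, 2-phenylethenyl in place of 4-chlorophenyl gives an at least 11-fold higher number from compound 1 to compound 3 (1.04 log units; beyond the scatter). This shows that the group at this place can change the result strongly, which the earlier step, on a different part of the shared core, could not show. Compound 3 stands at a limit of the assay, not at a number: the limit of > 100000 nM in this assay, at which 1 of the 3 values shown sits.

Going by these compounds, the true distance between compound 3 and compound 1 therefore stays open. So does whether the chlorine or the double bond matters more, which a plain phenyl or a 4-aminophenyl group in this place could help to separate.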